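From ring amide to ether-linked butyl amide

A few compounds are considered here, and "the series" means these few. Any claim that something is new, unique, unknown or untested is made for them only; others in the source may bear on it.

Two measured compounds share one core. Compound 1 `COCCNC(=O)C1CCN(c2nc(N)c3cc(OC)c(OC)cc3n2)CC1` in an assay on isolated protein for displacement of a labelled ligand from Adrenergic receptor alpha-1 (Rattus norvegicus) (on this read-out lower numbers stand for stronger inhibition and higher numbers for weaker inhibition), gives 1.13 nM. Compound 2 `COc1cc2nc(N3CCC(C(=O)N4CCOCC4)CC3)nc(N)c2cc1OC` in this assay gives 1.14 nM. The step of a 1.0-fold higher number from compound 1 to compound 2 (0.00 log units; within the scatter) alters the number hardly at all. On the numbers at hand compound 2 stands alongside compound 1, the pair lying within the scatter of each other.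

Compound 3 `CCCCNC(=O)COC1CCN(c2nc(N)c3cc(OC)c(OC)cc3n2)CC1` is not yet measured. It differs from compound 2 by (butylcarbamoyl)methoxy in place of (morpholin-4-yl)carbonyl on a saturated ring carbon. Within the data shown here, only one measured step bears on this change, and only loosely: a 1.0-fold higher number from compound 1 to compound 2 (0.00 log units; within the scatter) exchanged one group on a carbonyl carbon and moved the number by nothing beyond the scatter. The change to compound 3 is larger: the whole (morpholin-4-yl)carbonyl leaves and a (butylcarbamoyl)methoxy enters, while the shared core is kept intact. A step in this assay of about a 1.8-fold higher number from compound 2 to compound 3 (0.24 log units; within the scatter) toward a somewhat higher number is therefore expected, though it may well remain within the scatter. Compound 3 is estimated at 2 nM, with a range from 0.5 nM to 8 nM.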

Compound 3, inhibition constant: 0.79 nM
For compound 3 the middle estimate is 2.5-fold (0.40 log units) above the measured one; the range from low to high includes it.
By their numbers in this assay, from the lowest: compounds 3, 1 and 2 (each within the scatter of the next).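

Compound 3 carries its change on the saturated ring carbon itself rather than on a carbonyl carbon, and in this assay the step of a 1.4-fold lower number from compound 2 to compound 3 (0.16 log units; within the scatter) shows that the ring of the (morpholin-4-yl)carbonyl can leave and a hydrogen-bond donor can enter without the number moving beyond the scatter. The step of a 1.4-fold lower number from compound 1 to compound 3 (0.16 log units; within the scatter) gives the same reading when the group that leaves is the ringless (2-methoxyethyl)carbamoyl, so all three groups tried on this carbon sit within the scatter of one another, and none of the three compounds goes against this. Nothing available offers an explanation for this even picture.

The two parts of the (butylcarbamoyl)methoxy change together here, so the shares of the butyl chain and of the methoxy link in this result cannot be told apart. Whether the even picture holds once the amide at this carbon gives way to a plain amine, a carboxylic acid or a much longer chain is left open by these compounds.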